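Fluoro to amino at the assay limit

A few compounds are considered here, and "the series" means these few. Any claim that something is new, unique, unknown or untested is made for them only; others in the source may bear on it.

In a functional assay on SK-MEL-28 cells (Homo sapiens) for inhibition (on this read-out lower numbers stand for stronger inhibition and higher numbers for weaker inhibition), compound 2 `COc1ccc(/C=C/c2ccc3ccccc3c2)cc1F` gives > 5000 nM, which is a limit and not a number. Compound 1 `COc1ccc(/C=C/c2ccc3ccccc3c2)cc1` gives > 5000 nM, also a limit. Compound 3 `FC(F)(F)Oc1ccc(/C=C/c2ccc3ccccc3c2)cc1` gives > 5000 nM, again a limit. So the whole evidence so far is the limit of > 5000 nM in this assay, at which 3 of the 3 values shown sit.

The next compound, compound 4 `COc1ccc(/C=C/c2ccc3ccccc3c2)cc1N`, replaces the fluoro of compound 2 with amino: amino in place of fluoro on an aromatic carbon. The new group sits ortho to a methoxy group and meta to a large group.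

For the measured compounds named here, two measured steps bear on this change, and neither has a readable size: a step that the two limits leave unreadable from compound 1 to compound 2 and a step that the two limits leave unreadable from compound 1 to compound 3. Neither step brings in an amino group, so they offer no size to carry over. The safest expectation is therefore no clear shift in either direction, although a real number below the limit cannot be ruled out. The expected step is a number no higher from compound 2 to compound 4 (the limit leaves the size open). For compound 4 the estimated value is 5000 nM, with an expected range from 1500 nM to 15000 nM.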

Compound 4, half-maximal inhibitory concentration: > 5000 nM
Compound 4 ended at the assay's limit (the forecaster's own chance of this, stated with the estimate: 65%); the middle value lies on the limit itself.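

In this assay compound 4 gives > 5000 nM, which is a limit and not a number. Its steps from compound 1 and compound 2 join limit to limit and cannot be read. The compounds shown leave open whether amino, fluoro and hydrogen differ at all on this read-out.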